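The source may report more compounds than this note shows. Statements on the series, on what has been measured and on what is new or still open speak of the compounds shown alone.

Measured compounds:
Compound 1 `COc1cc(-c2ncnn2-c2cccc(N)c2)cc(OC)c1OC` — in a functional assay on Jurkat cells (Homo sapiens) for antiproliferative activity, read by MTT assay, with a stated time of 72 h (a lower number here means a stronger inhibitor, a higher number a weaker inhibitor), compound 1 gives > 10000 nM, which is a limit of the assay.
Compound 2 `COc1cc(-n2ncnc2-c2ccc(Cl)cc2)cc(OC)c1OC` — in this assay compound 2 gives > 10000 nM, a limit of the assay.
Compound 3 `COc1cc(-c2ncnn2-c2cccc([N+](=O)[O-])c2)cc(OC)c1OC` — in this assay compound 3 gives > 10000 nM, a limit of the assay.

Compound 2 thus stands at the limit, where every measured value sits (the limit of > 10000 nM in this assay, at which 3 of the 3 values shown sit). Within the data shown here, the one measured step, a step that the two limits leave unreadable from compound 1 to compound 3, runs between two limits and its size cannot be read, so no measured step shows how large a change on the shared core can be. Compound 4 `COc1cc(-n2ncnc2-c2ccc(SC)cc2)cc(OC)c1OC` differs from compound 2 in one place: methylsulfanyl in place of chloro on an aromatic carbon. Among the measured compounds shown here, no measured pair bears on methylsulfanyl in place of chloro. Compound 4 is therefore expected to stay near the limit, which is the step that the limit leaves unreadable from compound 2 to compound 4 expected. Compound 4 is estimated at 15000 nM, within 2000 nM to 100000 nM.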

Compound 4, half-maximal inhibitory concentration: 50 nM
Beside the measured number, compound 4's estimate is 300-fold (2.48 log units) above it; measured number below the stated range.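

In this assay, methylsulfanyl in place of chloro on an aromatic carbon, para to a large group, gives an at least 200-fold lower number from compound 2 to compound 4 (2.30 log units; beyond the scatter). Among these compounds, this shows that a single change at this position can move the read-out far beyond the scatter, which the earlier compounds could not show. Compound 4 is the only compound shown that comes off the limit: the limit of > 10000 nM in this assay, at which 3 of the 4 values shown sit.

Still open, as far as these compounds go, is how a methoxy group, a longer ethylsulfanyl chain or a methylsulfonyl group would read at this position. Also open, from the compounds shown here alone, is whether the sulfur atom itself or the whole methylsulfanyl group carries the step.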